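Swapping the acid chain on compound 3

The source may report more compounds than this note shows. Statements on the series, on what has been measured and on what is new or still open speak of the compounds shown alone.

Measured in a functional assay on A549 cells (Homo sapiens) for cytotoxicity, read by MTT assay; on this read-out lower numbers stand for stronger inhibition and higher numbers for weaker inhibition
compound 1 `CCOC(=O)C(C)Oc1c(-c2ccc(OC)cc2)oc2c(CC=C(C)C)c(O)cc(O)c2c1=O` gives 4600 nM
compound 2 `COc1ccc(-c2oc3c(CC=C(C)C)c(OC(C(=O)O)C(=O)O)cc(O)c3c(=O)c2OC(C(=O)O)C(=O)O)cc1` gives > 100000 nM as a limit, not a number
compound 3 `COc1ccc(-c2oc3c(CC=C(C)C)c(OC(C)C(=O)O)cc(O)c3c(=O)c2O)cc1` gives 15300 nM

Only two of these results are true numbers. Of those two, compound 3 has the higher, 15300 nM in this assay, and compound 1 sits lower at 4600 nM by a gap beyond the usual scatter. Compound 2 stands at > 100000 nM which is a limit of the assay.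

Compound 4 `COc1ccc(-c2oc3c(CC=C(C)C)c(OCCCC(=O)O)cc(O)c3c(=O)c2O)cc1` has not been measured yet. It carries 3-carboxypropyl in place of 1-carboxyethyl on an oxygen on an aromatic ring, and the rest of the molecule stays the same.

Going by the values given here, no measured pair in this small set shows a change of this kind, so the guidance is thin. Both groups are carboxy chains without a ring, and compound 3 at 15300 nM is the natural starting point, so no step beyond the scatter is expected in this assay. The expected change is a 1.0-fold lower number from compound 3 to compound 4 (0.01 log units; within the scatter) and it should stay within the usual scatter. For compound 4 the estimated value is 15000 nM with an expected range of 6000 nM to 45000 nM around it.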

Compound 4, half-maximal inhibitory concentration: 19100 nM
The estimate for compound 4 lay 1.3-fold (0.10 log units) below the measured number, within the range that was stated.
By their numbers in this assay, from the lowest: compound 1; then compounds 3 and 4 (each within the scatter of the next). At a limit, above all of these: compound 2.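

Going by these compounds alone, compound 3 and compound 4 differ in one place only, so this pair gives the first direct reading of that place in this assay. Replacing 1-carboxyethyl with 3-carboxypropyl on an oxygen on an aromatic ring gives a 1.2-fold higher number from compound 3 to compound 4 (0.10 log units; within the scatter), so at this oxygen, these two carboxy chains cannot be told apart in this read-out. Nothing among the results shown offers a reason why the two chains read alike.

Still open, on these data alone, is how other groups on this same oxygen would read, such as a chain ending in an amine, an amide, or a carboxy chain longer than 3-carboxypropyl. As far as these compounds go, it is also open whether the two chains would stay indistinguishable in a different cell line.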